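Silyl ether in place of the free hydroxyl hydrogen

The compounds below may be only part of what the source reports. "The series", "measured", "known", "first", "only" and "open" are said of these compounds alone.

Compound 3 `COc1cc(C2=C(c3cc(C)c(OC)c(C)c3)C(O)CC2=O)cc(OC)c1OC` carries a hydrogen on an oxygen on a saturated carbon of the shared core. In an ADME assay on KB cells (Homo sapiens) for cytotoxicity, read by MTT assay, with a stated time of 72 h (a higher number here means a weaker inhibitor, a lower number a stronger inhibitor), compound 3 gives only a limit of > 100 ug/mL and no number. The two related compounds sit at the same place: compound 1 `COc1ccc(C2=C(c3cc(OC)c(OC)c(OC)c3)CC(O[SiH2]C(C)(C)C)C2=O)cc1[N+](=O)[O-]` gives a limit of > 100 ug/mL in this assay and compound 2 `COc1ccc(C2=C(c3cc(OC)c(OC)c(OC)c3)CC(O)C2=O)cc1[N+](=O)[O-]` gives a limit of > 100 ug/mL in this assay as well. Compound 3 thus stands at the limit of > 100 ug/mL in this assay, at which 3 of the 3 values shown sit, together with both others, and no order among the three can be read. Among the compounds with values here, the one measured step at this position, a step that the two limits leave unreadable from compound 1 to compound 2, is unreadable because both of its ends sit at the limit of > 100 ug/mL in this assay, at which 3 of the 3 values shown sit. Compound 4 `COc1cc(C2=C(c3cc(C)c(OC)c(C)c3)C(O[SiH2]C(C)(C)C)CC2=O)cc(OC)c1OC` differs from compound 3 by a group of 5 heavy atoms (4 carbon, 1 silicon; no ring) in place of a hydrogen atom, on an oxygen on a saturated carbon. This is the same exchange as between compound 1 and compound 2 taken the other way round, and that pair yields no readable size, so no step beyond the scatter in either direction can be expected in this assay. The limit is expected to persist: compound 4 is estimated at 150 ug/mL in this assay with a range from 60 ug/mL to 400 ug/mL. The step from compound 3 to compound 4 is expected to be a step that the limit leaves unreadable from compound 3 to compound 4 in size, most likely again reported only as a limit.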

Compound 4, half-maximal inhibitory concentration: 40 ug/mL
The estimate for compound 4 lay 3.8-fold (0.57 log units) above the measured number; measured number outside the range, below it.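

Within the data shown here, on the oxygen on a saturated carbon, putting the group of 5 heavy atoms (4 carbon, 1 silicon; no ring) in place of the hydrogen atom gives the only readable step at this position in this assay: an at least 2.5-fold lower number from compound 3 to compound 4 (0.39 log units; beyond the scatter). The same exchange between compound 1 and compound 2 cannot be read, so the change is now seen to matter on the core of compound 3, while on the core of compound 2 nothing can be said, and compound 4 alone has left the shared limit: the limit of > 100 ug/mL in this assay, at which 3 of the 4 values shown sit.
The value of compound 3, > 100 ug/mL, is a limit and not a number.

As far as these compounds go, whether the step belongs to this group in particular or to any replacement of the hydrogen atom stays open, and a methyl ether or an acetate on the same oxygen of the core of compound 3 would bear on that. Among these compounds, also open is whether the step holds on other cores, since the only other pair with this exchange gives no readable size.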